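This account rests on a few compounds, and the source may have more. Where it says the series, first, only, none or still open, it means among the compounds named here.

Measured so far:
- Compound 1 `O=C(Cc1csc2nc(-c3ccc(Br)cc3)cn12)N/N=C/c1ccccc1O` gives 6170 nM
- Compound 2 `COc1cccc(OC)c1/C=N/NC(=O)Cc1csc2nc(-c3ccc(Br)cc3)cn12` gives 11500 nM

In a functional assay on A549 cells (Homo sapiens) for inhibition, read by sulforhodamine B assay, with a stated time of 48 h (a higher number here means a weaker inhibitor of growth, a lower number a stronger inhibitor of growth), compound 2 gives 11500 nM and stands level with compound 1 within the usual scatter, so these two cannot be ranked.

Compound 3 `O=C(Cc1csc2nc(-c3ccc(Br)cc3)cn12)N/N=C/c1ccc(Cl)cc1Cl` keeps the shared core and alters one group: 2,4-dichlorophenyl in place of 2,6-dimethoxyphenyl on a carbon with a double bond to nitrogen. In words, this is 2,4-dichlorophenyl in place of 2,6-dimethoxyphenyl on a carbon with a double bond to nitrogen.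

Going by the values given here, only one measured step bears on this change, because it altered the same group: a 1.9-fold higher number from compound 1 to compound 2 (0.27 log units; within the scatter). Among the compounds with values here, no measured compound carries chlorine, so the direct evidence is thin and the range must stay wide. No step beyond the scatter is expected, in either direction.

The expected step is a 1.4-fold lower number from compound 2 to compound 3 (0.16 log units; within the scatter). For compound 3 the estimated value is 8000 nM, with an expected range from 3000 nM to 20000 nM.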

Compound 3, concentration for 50% growth inhibition: 17000 nM
The estimate for compound 3 lay 2.1-fold (0.33 log units) below the measured number; measured number inside the range.
By their numbers in this assay, from the lowest: compounds 1, 2 and 3 (each within the scatter of the next, the first and the last beyond it).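

Replacing 2-hydroxyphenyl with 2,4-dichlorophenyl gives a 2.8-fold higher number from compound 1 to compound 3 (0.44 log units; beyond the scatter) in this assay and is the first change at this position shown to exceed the scatter, though only modestly, so this position can affect growth inhibition to a measurable degree. Replacing 2,6-dimethoxyphenyl with the same group gives a 1.5-fold higher number from compound 2 to compound 3 (0.17 log units; within the scatter) and separates neither group from the other, so compound 2 stays level with both compound 1 and compound 3, and only the two ends of the series can be ranked. Nothing measured here explains the difference between compound 1 and compound 3.

Every compound shown carries a six-membered aromatic ring at this position, so the effect of a simple alkyl chain there remains open. As far as these compounds go, it is also open how a ring bearing an amine or a carboxylic acid would compare.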